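Swapping dichlorophenyl for hydroxyphenyl on a shared core

The compounds below may be only part of what the source reports. "The series", "measured", "known", "first", "only" and "open" are said of these compounds alone.

Values measured in a functional assay on SK-OV-3 cells (Homo sapiens) for antiproliferative activity, read by MTT assay, with a stated time of 24 h (a higher number here means a weaker inhibitor, a lower number a stronger inhibitor), are these
- compound 1 `COc1ccc(/C=C/C(=O)c2ccc(OC)c3c2OC(C)(C)C=C3)c(F)c1` gives 4880 nM
- compound 2 `COc1ccc(C(=O)/C=C/c2ccc(-n3ccnc3)cc2)c2c1C=CC(C)(C)O2` gives 7200 nM
- compound 3 `COc1ccc(C(=O)/C=C/c2ccc(Cl)c(Cl)c2)c2c1C=CC(C)(C)O2` gives 9940 nM

Compound 3 has the highest number of the three, but its gap to compound 2 lies within the scatter, so only compound 1 sits clearly lower. Compound 4 `COc1ccc(C(=O)/C=C/c2ccc(O)cc2)c2c1C=CC(C)(C)O2` differs from compound 3 on a double-bonded chain carbon bound to a double-bonded chain carbon, where 4-hydroxyphenyl stands in place of 3,4-dichlorophenyl (4-hydroxyphenyl in place of 3,4-dichlorophenyl on a double-bonded chain carbon bound to a double-bonded chain carbon). Within the data shown here, the one measured step at this place, a 2.0-fold higher number from compound 1 to compound 3 (0.31 log units; beyond the scatter) and modest in size, involves other groups, and no measured compound carries 4-hydroxyphenyl. That step still suggests limited movement here, so in this assay a small drop, probably within the scatter, is expected (a 1.3-fold lower number from compound 3 to compound 4 (0.12 log units; within the scatter)). For compound 4 the estimate is 7500 nM (expected range 3000 nM to 18000 nM).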

Compound 4, half-maximal inhibitory concentration: > 10000 nM
Compound 4 was reported as a limit; the forecaster's own chance of this, stated with the estimate: 8%; middle value at least 1.3-fold (0.12 log units) away from the limit.
By their numbers in this assay, from the lowest: compounds 1, 2 and 3 (each within the scatter of the next, the first and the last beyond it). At a limit, above all of these: compound 4.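

In this assay compound 4 gives > 10000 nM, which is a limit and not a number. Placing 4-hydroxyphenyl at this position in place of 3,4-dichlorophenyl gives a number no lower from compound 3 to compound 4 (the limit leaves the size open), and the limit means the size of that step cannot be read. Replacing 2-fluoro-4-methoxyphenyl gives an at least 2.0-fold higher number from compound 1 to compound 4 (0.31 log units; beyond the scatter), a clear loss, while hydroxy in place of 1H-imidazol-1-yl gives an at least 1.3-fold higher number from compound 2 to compound 4 (0.14 log units; that floor lies within the scatter).

On these data alone, the true value of compound 4 remains open. So does the effect of an amine or a carboxylic acid in place of the hydroxy group on the aromatic carbon.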